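This account rests on a few compounds, and the source may have more. Where it says the series, first, only, none or still open, it means among the compounds named here.

In a physicochemical assay for solubility, using the shake flask method, in simulated intestinal fluid, measured as kinetic solubility, with a stated time of 2 h, at 25 degrees C, at pH 6.5 (a higher number here means a more soluble compound, a lower number a less soluble compound), compound 1 (`Cc1nc(C#N)c(N)c2c1C(=O)N(Cc1ccccc1)C2=O`) gives < 5000 nM as a limit and not a number. Compound 2 (`Cc1nnc(-c2nc(C)c3c(c2N)C(=O)N(Cc2ccccc2)C3=O)o1`) likewise gives only a limit at < 5000 nM and stands there without a number. Compound 3 (`Cc1nc(-c2nc(C(F)(F)F)no2)c(N)c2c1C(=O)N(Cc1ccccc1)C2=O`) carries 3-(trifluoromethyl)-1,2,4-oxadiazol-5-yl in place of 5-methyl-1,3,4-oxadiazol-2-yl on an aromatic carbon and is otherwise the same. Among the compounds with values here, the one measured step that the two limits leave unreadable from compound 1 to compound 2 has no readable size and the evidence is only the limit of < 5000 nM in this assay, at which 2 of the 2 values shown sit, here, so no step beyond the scatter is expected in this assay and no direction can be given. The expected step (a step that the limit leaves unreadable from compound 2 to compound 3) is therefore small. Compound 3 is estimated at 2000 nM with an expected range from 400 nM to 5000 nM and may well read only as a limit.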

Compound 3, solubility: < 5000 nM
Compound 3: only a limit was reported; the forecaster's own chance of this, stated with the estimate: 85%; the middle value lies beyond the limit too.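

In this assay compound 3 gives < 5000 nM, a limit and not a number. Within the data shown here, no step among compound 1, compound 2 and compound 3 can be read. The compounds shown leave open whether the cyano, 5-methyl-1,3,4-oxadiazol-2-yl and 3-(trifluoromethyl)-1,2,4-oxadiazol-5-yl compounds differ at all in solubility.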